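The source may report more compounds than this note shows. Statements on the series, on what has been measured and on what is new or still open speak of the compounds shown alone.

Series notes. Within the data shown here, in an assay on isolated protein for inhibition of Polyunsaturated fatty acid 5-lipoxygenase (Homo sapiens) (a higher number here means a weaker inhibitor, a lower number a stronger inhibitor), compound 1 `O=C1CCCN(c2cccc(CO)c2)N1` gives 53000 nM and compound 2 `N#Cc1cccc(N2CCCC(=O)N2)c1` gives 9300 nM; compound 2 stands lowest of the two, the only change being a 5.7-fold lower number from compound 1 to compound 2 (0.76 log units; beyond the scatter). Compound 3 `O=C1CCCN(c2cccc(F)c2)N1` is not yet measured; it differs from compound 2 by fluoro in place of cyano on an aromatic carbon. Among the measured compounds shown here, the one measured step touches the same aromatic carbon but swaps hydroxymethyl for cyano, so it bears on this change only loosely, and no step to a fluoro substituent has been measured. A shift in this assay of a 2.2-fold higher number from compound 2 to compound 3 (0.33 log units; beyond the scatter) toward a higher number is therefore expected for compound 3, with compound 1 marking the likely upper bound. Compound 3 is estimated at 20000 nM, in the range 6000 nM to 60000 nM.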

Compound 3, half-maximal inhibitory concentration: 5500 nM
Beside the measured number, compound 3's estimate is 3.6-fold (0.56 log units) above it; the measured number lies below the stated range.
By their numbers in this assay, from the lowest: compounds 3 and 2 (each within the scatter of the next); then compound 1.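

In this assay, fluoro in place of cyano on this aromatic carbon gives a 1.7-fold lower number from compound 2 to compound 3 (0.23 log units; within the scatter), so the nitrile and fluoro cannot be told apart here, although the swap drops a triple bond and a hydrogen-bond acceptor. Fluoro in place of hydroxymethyl gives a 9.6-fold lower number from compound 1 to compound 3 (0.98 log units; beyond the scatter), so hydroxymethyl now stands apart from both other substituents, not just from the nitrile. On these data alone, whether an amine, a carboxylic acid or a longer chain on this carbon would track with hydroxymethyl or with the other two remains open. No measurement shown accounts for the separation of hydroxymethyl from the other two substituents.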